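Swapping a chain-end hydroxyl for dimethylamino in a kinase inhibitor

The source may hold more compounds than are shown below. What is called first, only, known or untested is meant among the compounds shown, and "the series" means these compounds.

Three related compounds have been measured in an assay for inhibition of RAC-alpha serine/threonine-protein kinase (Homo sapiens), read by HTRF, with a stated time of 1 h; on this read-out lower numbers stand for stronger inhibition and higher numbers for weaker inhibition. Compound 1 `Cn1ncc(Cl)c1-c1cc(C(=O)N[C@@H]2CN[C@H](CCNS(C)(=O)=O)C[C@H]2c2ccc(F)c(F)c2)oc1Cl` gives 3.29 nM, compound 2 `Cn1ncc(Cl)c1-c1cc(C(=O)N[C@@H]2CN[C@H](CCCO)C[C@H]2c2ccc(Cl)c(Cl)c2)oc1Cl` gives 2.56 nM, and compound 3 `CC(=O)NCC[C@@H]1C[C@@H](c2ccc(F)c(F)c2)[C@H](NC(=O)c2cc(-c3c(Cl)cnn3C)c(Cl)o2)CN1` gives 2.49 nM. All three numbers lie within the usual scatter of one another, so compound 2 sits among them without standing apart from either neighbour. For the measured compounds named here, the only single-point step measured so far, a 1.3-fold lower number from compound 1 to compound 3 (0.12 log units; within the scatter), changes the end of the side chain and leaves the number essentially unchanged.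

Compound 4 `CN(C)CC[C@@H]1C[C@@H](c2ccc(Cl)c(Cl)c2)[C@H](NC(=O)c2cc(-c3c(Cl)cnn3C)c(Cl)o2)CN1` differs from compound 2 by dimethylamino in place of hydroxymethyl on a saturated chain carbon, two bonds along the chain from a saturated ring carbon. Going by the values given here, no measured step covers this exact swap, but the one step that does alter the chain end, from compound 1 to compound 3, stayed within the scatter. The expectation for compound 4 is therefore a number close to that of compound 2, with a 1.2-fold higher number from compound 2 to compound 4 (0.07 log units; within the scatter) expected to fall within the scatter. The estimate for compound 4 in this assay is 3 nM, with a range from 1 nM to 10 nM.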

Compound 4, half-maximal inhibitory concentration: 3.4 nM
Compound 4: the middle estimate sits 1.1-fold (0.05 log units) below what was measured; low and high end bracket the measured number.
By their numbers in this assay, from the lowest: compounds 3, 2, 1 and 4 (each within the scatter of the next).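

In this assay, dimethylamino in place of hydroxymethyl gives a 1.3-fold higher number from compound 2 to compound 4 (0.12 log units; within the scatter) and stays within the scatter. The earlier step exchanged only methylsulfonyl for acetyl on an amine nitrogen, whereas this one shows that the chain can end in dimethylamino, with 0 hydrogen-bond donors, as well as in a hydroxyl-bearing group with 1, and the number still does not move beyond the scatter. No measurement shown here explains why this swap leaves the number within the scatter.

Still open, from the compounds shown here alone, is whether a carboxylic acid at the chain end, or a longer chain carrying dimethylamino, would also stay within the scatter. Also open, going by these compounds, is whether dimethylamino would give the same result in the fluorine-bearing compounds, since this step was read only with the two chlorines of compound 2 in place.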